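The compounds below may be only part of what the source reports. "The series", "measured", "known", "first", "only" and "open" are said of these compounds alone.

Series notes, measured compounds in a functional assay on A549 cells (Homo sapiens) for antiproliferative activity, read by MTT assay, with a stated time of 72 h; a higher number here means a weaker inhibitor, a lower number a stronger inhibitor:
- compound 1 `COc1cc(O)c2c(=O)n(-c3ccccc3)ccc2c1` gives 27900 nM
- compound 2 `COc1cc(O)c2c(=O)n(-c3cccc(C(=O)N4CCCCC4)c3)ccc2c1` gives 14200 nM
- compound 3 `COc1cc(O)c2c(=O)n(-c3cccc(C(N)=O)c3)ccc2c1` gives 24800 nM

Compound 2 has the lowest number of the three, yet its steps are small: a 2.0-fold lower number from compound 1 to compound 2 (0.29 log units; within the scatter) and a 1.7-fold higher number from compound 2 to compound 3 (0.24 log units; within the scatter); the third step, a 1.1-fold lower number from compound 1 to compound 3 (0.05 log units; within the scatter), is likewise small. All three measured changes sit on the pendant phenyl ring.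

Compound 4 `C=CC(=O)Nc1c(OC)cc(O)c2c(=O)n(-c3cccc(C(=O)N4CCCCC4)c3)ccc12` differs from compound 2 elsewhere: (vinylcarbonyl)amino in place of hydrogen on an aromatic carbon. Among the measured compounds shown here, no measured step touches this position or this group, so the measured steps give no direction for it; the expectation can only be drawn from the flat picture in this assay. The step from compound 2 to compound 4 is therefore expected to be a 1.4-fold lower number from compound 2 to compound 4 (0.15 log units; within the scatter), with wide uncertainty. Compound 4 is estimated at 10000 nM, range 2000 nM to 40000 nM.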

Compound 4, half-maximal inhibitory concentration: 14700 nM
Estimate against measurement, compound 4: 1.5-fold (0.17 log units) below; the range from low to high includes it.
By their numbers in this assay, from the lowest: compounds 2, 4, 3 and 1 (each within the scatter of the next).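

Among the compounds shown here, this is the only measured step on the shared core rather than on the pendant phenyl ring. In this assay it reads a 1.0-fold higher number from compound 2 to compound 4 (0.02 log units; within the scatter), so (vinylcarbonyl)amino on this aromatic carbon, ortho to a methoxy group, leaves the number within the scatter of hydrogen. No measurement available here bears on the reason for this result.

Open, as far as these compounds go, is whether a plain amino group or a propanoylamino group on this carbon would read like (vinylcarbonyl)amino. Also open, from the compounds shown here alone, is whether (vinylcarbonyl)amino would read the same on compound 1, which lacks the (piperidin-1-yl)carbonyl group.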